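This account rests on a few compounds, and the source may have more. Where it says the series, first, only, none or still open, it means among the compounds named here.

Measured compounds in a functional assay on HEK293 cells for positive allosteric modulation of metabotropic glutamate receptor 5 (Homo sapiens), read by calcium flux; a lower number here means a smaller maximal response, a higher number a larger maximal response:

- Compound 1, `O=C1c2cc(COc3ccccc3)nn2CCN1c1ccc(F)cc1`: 79%
- Compound 2, `O=C1c2cc(COc3ccccc3)nn2CCN1c1ccncc1`: 72%
- Compound 3, `O=C1c2cc(COc3ccccc3)nn2CCN1c1ccc(F)cn1`: 72%

Compound 1 stands highest of the three numbers shown, though the step of a number 7 percentage points lower from compound 1 to compound 2 (within the scatter) and the step of a number 7 percentage points lower from compound 1 to compound 3 (within the scatter) are both within the scatter, so the three compounds cannot be told apart on these figures. The step of no change at the digits printed from compound 2 to compound 3 (within the scatter) adds nothing further. All three measured steps change only the aromatic group on the amide-type nitrogen in the ring; none of them touches the position altered in compound 4.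

Compound 4, `CC(Oc1ccccc1)c1cc2n(n1)CCN(c1ccc(F)cc1)C2=O`, differs from compound 1 in one place: methyl in place of hydrogen on a saturated chain carbon bound to an aromatic carbon and an oxygen on an aromatic ring. Within the data shown here, no measured step bears on this change, so the measured series gives no direction for it. With the nearby steps all within the scatter, compound 4 is expected to behave much like compound 1, with a step of no change at the digits printed from compound 1 to compound 4 (within the scatter) that is not expected to exceed the scatter. The estimate for compound 4 in this assay is 79%, within a range from 65% to 90%.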

Compound 4, largest response reached (Emax), in percent of the reference or control that the assay uses: 65%
For compound 4 the middle estimate is 14 percentage points above the measured one; measured number inside the range.
By their numbers in this assay, from the lowest: compounds 4, 2, 3 and 1 (each within the scatter of the next, the first and the last beyond it).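

In this assay the methyl in place of hydrogen on a saturated chain carbon bound to an aromatic carbon and an oxygen on an aromatic ring gives a number 14 percentage points lower from compound 1 to compound 4 (beyond the scatter) and is the only step in the series shown that lies beyond the scatter. This position therefore registers a change as small as one added carbon, though the step is modest, whereas the three aromatic groups on the amide-type nitrogen could not be told apart. No measurement at hand accounts for this lower maximal response.

On these data alone, whether an ethyl group, a cyclopropyl ring or a fluorine on the same carbon would give a lower number or restore the response remains open. Also open, as far as these compounds go, is whether the methyl has a similar effect with pyridin-4-yl or 5-fluoropyridin-2-yl on the nitrogen.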